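The source may hold more compounds than are shown below. What is called first, only, known or untested is meant among the compounds shown, and "the series" means these compounds.

Measured in a functional assay on SK-HEP1 cells (Homo sapiens) for inhibition, read by MTT assay, with a stated time of 72 h; a lower number here means a stronger inhibitor, a higher number a weaker inhibitor:
- Compound 1 `Nc1ncnc2c1c(-c1cnc3[nH]ccc3c1)nn2CCCCCC(=O)NO`: > 150000 nM (a limit)
- Compound 2 `Nc1ncnc2c1c(-c1cnc3[nH]ccc3c1)nn2CCCCCCC(=O)NO`: 14700 nM

In this assay, going by the values given here, compound 2 at 14700 nM holds the only actual number. The value of compound 1 is a limit. Compound 3 `Nc1nc2cc(-c3nn(CCCCCCC(=O)NO)c4ncnc(N)c34)ccc2o1` keeps the chain of compound 2 and changes one group: a group of 10 heavy atoms (7 carbon, 2 nitrogen, 1 oxygen; one five-membered aromatic ring with 2 hetero atoms, one six-membered aromatic ring of carbon only) in place of a group of 9 heavy atoms (7 carbon, 2 nitrogen; one five-membered aromatic ring with 1 hetero atom, one six-membered aromatic ring with 1 hetero atom), on an aromatic carbon. The entering group is 2-amino-1,3-benzoxazol-5-yl, on an aromatic carbon of a five-membered aromatic ring with 2 nitrogen. Among the compounds with values here, the only measured step, an at least 10-fold lower number from compound 1 to compound 2 (1.00 log units; beyond the scatter), lies in the chain and not at this carbon, so it sets no size for the new change. With no direct measurement, the estimate is uncertain, but a clear move towards a lower number is expected. The expected step is a 7.4-fold lower number from compound 2 to compound 3 (0.87 log units; beyond the scatter). For compound 3 the expected value in this assay is 2000 nM, within an estimated range of 250 nM to 12000 nM.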

Compound 3, half-maximal inhibitory concentration: 2690 nM
For compound 3 the middle estimate is 1.3-fold (0.13 log units) below the measured one; low and high end bracket the measured number.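

In this assay, the aromatic carbon of the five-membered aromatic ring with 2 nitrogen proves to be a second place where the number can move: with the chain kept, 2-amino-1,3-benzoxazol-5-yl in place of the earlier group gives a 5.5-fold lower number from compound 2 to compound 3 (0.74 log units; beyond the scatter). Going by these compounds alone, until now, the only measured step lay in the chain, so this is the first sign that the group on this carbon also matters. The change alters both rings of the group and its count of hydrogen-bond acceptors at once, and nothing shown gives a reason for the step or assigns it to one part of the group.

The compounds shown leave open whether the amine on the benzoxazole is needed, or whether a plain hydrogen or a methyl there would serve as well. They also leave open how a shorter or longer chain would behave with this group in place.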